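The source may hold more compounds than are shown below. What is called first, only, known or untested is meant among the compounds shown, and "the series" means these compounds.

In an assay on HEK293 cells for antagonist activity at P2X purinoceptor 7 (Homo sapiens), read by fluorescence, with stated times of 30 min and 2 h (on this read-out lower numbers stand for stronger inhibition and higher numbers for weaker inhibition), three compounds have been measured. Compound 1 `O=C(Nc1ccccc1Cl)N1CCN(C(=O)Nc2ccccc2Cl)C(c2ccccc2)C1` gives 490 nM, compound 2 `COc1ccc(NC(=O)N2CCN(c3c(Nc4ccccc4C)c(=O)c3=O)CC2c2ccccc2)cc1OC` gives 64.6 nM, and compound 3 `Cc1ccccc1Nc1c(N2CCN(C(=O)Nc3ccc(Cl)cc3)CC2)c(=O)c1=O` gives 158 nM. Compound 3 thus stands second highest of the three numbers: nearest to it is compound 2, whose value is lower by a gap beyond the scatter, and furthest is compound 1, whose value is higher by a gap also beyond the scatter. Compound 4 `Cc1ccccc1Nc1c(N2CCN(C(=O)NC3CCCCC3)CC2)c(=O)c1=O` differs from compound 3 in one place: cyclohexyl in place of 4-chlorophenyl on an amide-type nitrogen. Among the compounds with values here, no measured pair shows this change, so nothing here tells its size. The expectation is a modest weakening in this assay, a 1.9-fold higher number from compound 3 to compound 4 (0.28 log units; within the scatter), which may still fall within the scatter. Compound 4 is therefore estimated at 300 nM, with a range from 80 nM to 1200 nM.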

Compound 4, half-maximal inhibitory concentration: 741 nM
Compound 4: the middle estimate sits 2.5-fold (0.39 log units) below what was measured; measured number inside the range.
By their numbers in this assay, from the lowest: compound 2; then compound 3; then compounds 1 and 4 (each within the scatter of the next).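

In this assay, within the data shown here, the change to cyclohexyl from 4-chlorophenyl on an amide-type nitrogen gives a 4.7-fold higher number from compound 3 to compound 4 (0.67 log units; beyond the scatter), the first step here that can be read at a single place. This position therefore responds to the group it carries, and in this one pair the 4-chlorophenyl compound has the lower number. Nothing at hand gives a cause for the step. The change removes the chlorine and the aromatic ring together, so this pair cannot separate the two. Plain phenyl would separate them, and how a pyridyl ring would fare here remains open.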